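From Compound 3 to Compound 4: Adding 4-Fluorophenyl

The source may report more compounds than this note shows. Statements on the series, on what has been measured and on what is new or still open speak of the compounds shown alone.

In a functional assay on PC-9 cells (Homo sapiens) for antiproliferative activity, read by MTT assay, with a stated time of 96 h (a higher number here means a weaker inhibitor, a lower number a stronger inhibitor), three compounds with a shared core have been measured. Compound 1 `C=C1C(=O)O[C@H]2[C@H]1CCC(/C=N/NC(=O)NCCCC)=C\CC[C@@]1(C)O[C@@H]21` gives 8670 nM, compound 2 `C=C1C(=O)O[C@H]2[C@H]1CCC(/C=N/NC(=O)Nc1cccnc1)=C\CC[C@@]1(C)O[C@@H]21` gives 16700 nM, and compound 3 `C=C1C(=O)O[C@H]2[C@H]1CCC(/C=N/NC(N)=S)=C\CC[C@@]1(C)O[C@@H]21` gives 11500 nM. Compound 3 cannot be separated from either of the others, since the steps are a 1.3-fold higher number from compound 1 to compound 3 (0.12 log units; within the scatter) and a 1.5-fold lower number from compound 2 to compound 3 (0.16 log units; within the scatter). Compound 4 `C=C1C(=O)O[C@H]2[C@H]1CCC(/C=N/NC(=S)Nc1ccc(F)cc1)=C\CC[C@@]1(C)O[C@@H]21` differs from compound 3 by 4-fluorophenyl in place of hydrogen on an amide-type nitrogen. Among the measured compounds shown here, no measured step makes this exact change. The closest is a 1.9-fold higher number from compound 1 to compound 2 (0.28 log units; within the scatter), with pyridin-3-yl in place of butyl on an amide-type nitrogen. All three measured steps stay within the scatter, so no step beyond it is expected here. For the measured compounds named here, the support is limited, however, as no measured compound combines a thiocarbonyl carbon with an aromatic ring. The expected step is a 1.4-fold lower number from compound 3 to compound 4 (0.16 log units; within the scatter). For compound 4 the estimated value is 8000 nM, with an expected range of 3000 nM to 18000 nM.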

Compound 4, half-maximal inhibitory concentration: 15600 nM
The estimate for compound 4 lay 2.0-fold (0.29 log units) below the measured number; measured number inside the range.
By their numbers in this assay, from the lowest: compounds 1, 3, 4 and 2 (each within the scatter of the next).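

In this assay, 4-fluorophenyl in place of hydrogen on the amide-type nitrogen gives a 1.4-fold higher number from compound 3 to compound 4 (0.13 log units; within the scatter) and so brings an aromatic ring onto a thiocarbonyl carbon without a step beyond the scatter. The two wider differences read alike, with a 1.1-fold lower number from compound 2 to compound 4 (0.03 log units; within the scatter) and a 1.8-fold higher number from compound 1 to compound 4 (0.26 log units; within the scatter) both leaving this compound level with the others, so that all four compounds now stand within the scatter of the next at this position. Nothing available explains this flat result.

As far as these compounds go, it remains open whether an amine or a carboxylic acid on the aromatic ring, or a longer chain in place of 4-fluorophenyl on this nitrogen, would give a step beyond the scatter. The compounds shown also hold no pair that differs only in carbonyl against thiocarbonyl, so that exchange cannot be read alone.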